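Chromone ethers: methyl to nitrile on the benzyl ring

This account rests on a few compounds, and the source may have more. Where it says the series, first, only, none or still open, it means among the compounds named here.

Measured so far:
- compound 1, `Cc1cccc(COc2ccc3occc(=O)c3c2)c1`; in an assay on microsomes for inhibition of Amine oxidase [flavin-containing] B (Homo sapiens), read by fluorescence and spectrophotometry, with a stated time of 20 min (a higher number here means a weaker inhibitor, a lower number a stronger inhibitor), compound 1 gives 19 nM
- compound 2, `Cc1ccc(COc2ccc3occc(=O)c3c2)cc1`; in this assay compound 2 gives 6 nM
- compound 3, `N#Cc1cccc(COc2ccc3occc(=O)c3c2)c1`; in this assay compound 3 gives 76 nM

Compound 2 has the lowest number of the three; the difference between the cores of compound 1 and compound 2 is not broken down here.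

Among the compounds with values here, the one measured step with a single change is a 4.0-fold higher number from compound 1 to compound 3 (0.60 log units; beyond the scatter), the change being (cyano in place of methyl on an aromatic carbon).

Not yet measured is compound 4, `N#Cc1ccc(COc2ccc3occc(=O)c3c2)cc1`, which differs from compound 2 by cyano in place of methyl on an aromatic carbon. This is the same kind of change as from compound 1 to compound 3, though the place differs: in compound 3 the new group sits meta to a large group, in compound 4 para to a large group.

Within the data shown here, for compound 4 the expected step is a 3.7-fold higher number from compound 2 to compound 4 (0.56 log units; beyond the scatter), set near the measured one because a 4.0-fold higher number from compound 1 to compound 3 (0.60 log units; beyond the scatter) is the only guide, with the different place adding uncertainty. The estimate for compound 4 in this assay is 22 nM, expected to lie between 8 nM and 60 nM.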

Compound 4, half-maximal inhibitory concentration: 22 nM
For compound 4 middle estimate and measured number coincide at the digits printed, within the range that was stated.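

In this assay, cyano in place of methyl on an aromatic carbon gives a 3.7-fold higher number from compound 2 to compound 4 (0.56 log units; beyond the scatter), with the new group para to a large group in compound 4. Within the data shown here, on these two cores, the size of the change carries over despite the different place of the group, and the two steps do not differ: the same change on two cores in this assay, a 4.0-fold higher number (0.60 log units; beyond the scatter) from compound 1 to compound 3 and a 3.7-fold higher number (0.56 log units; beyond the scatter) from compound 2 to compound 4, 1.1-fold (0.04 log units) apart, within the scatter of two such steps This is only one pair of steps, so it shows no general rule for the series, and it does not show why the number rises on both cores or whether the agreement would hold on a third core.

Still open, going by these compounds, is whether other groups in the same place, such as an amine, a carboxylic acid or a longer chain, would follow the step seen with cyano. Also open, on these data alone, is whether the shared step extends beyond this one assay, since all of the values here come from this assay.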